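Compound 1 to compound 4: a shorter chain

This account rests on a few compounds, and the source may have more. Where it says the series, first, only, none or still open, it means among the compounds named here.

Within the data shown here, in a physicochemical assay for lipophilicity, measured as octanol-water partition (on this read-out lower numbers stand for lower lipophilicity and higher numbers for higher lipophilicity), compound 1 (`CCCCCCCCc1cn(C/C=C(/C)CCC=C(C)C)nn1`) gives 6.92 as its value, the second highest of the three numbers so far. Compound 3 (`CCCCCCCCc1cn(C/C=C(/C)CC/C=C(\C)CCC=C(C)C)nn1`) stands nearest at 8.76 on the high side, and compound 2 (`CCCc1cn(C/C=C(/C)CCC=C(C)C)nn1`) stands furthest at 4.05 on the low side. Both gaps lie beyond the scatter.

The next compound is compound 4 (`CCCCCCCCc1cn(CC=C(C)C)nn1`). The difference from compound 1 is hydrogen in place of 3-methylbut-2-en-1-yl on a saturated chain carbon bound to a double-bonded chain carbon and, in words, it is hydrogen in place of 3-methylbut-2-en-1-yl on a saturated chain carbon bound to a double-bonded chain carbon.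

The closest evidence is a number 1.84 log units higher from compound 1 to compound 3 (beyond the scatter) in size, large and beyond the scatter. That step places the same group at the same kind of carbon, so it is the present change read in reverse. The step of a number 2.87 log units lower from compound 1 to compound 2 (beyond the scatter) in size, also large, removes pentyl from the other chain and bears only loosely, as a second case of a fall on losing a chain portion. Each kind of change rests on a single pair.

A large fall in this assay is therefore expected, close in size to the first step. The expected step is a number 1.82 log units lower from compound 1 to compound 4 (beyond the scatter) by this estimate. For compound 4 the estimated value is 5.1 with an expected range from 4.7 to 5.5 in this read-out.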

Compound 4, partition coefficient: 4.92
Compound 4: the middle estimate sits 0.18 log units above what was measured; measured number inside the range.
By their numbers in this assay, from the lowest: compound 2; then compound 4; then compound 1; then compound 3.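

In this assay the change on a saturated chain carbon bound to a double-bonded chain carbon can now be read on both sides of compound 1: hydrogen in place of 3-methylbut-2-en-1-yl gives a number 2.00 log units lower from compound 1 to compound 4 (beyond the scatter) while the reverse kind of change gives a number 1.84 log units higher from compound 1 to compound 3 (beyond the scatter) as the matching step upward. Compound 4, compound 1 and compound 3 therefore stand in rising order as the chain on this side grows by this unit, and no compound among these three goes against that order, although it rests on only two steps, both taken from compound 1 with the octyl side unchanged. No measurement shown gives a reason for the size of either step.

Whether the same change gives a step of similar size when the other chain is shorter, as in compound 2, stays open, since no pair of that kind is shown. Also open, going by these compounds, is how this position responds to a group other than a plain hydrocarbon chain, such as a hydroxyl group, an amine or a carboxylic acid at the end of the chain.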